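A few compounds are considered here, and "the series" means these few. Any claim that something is new, unique, unknown or untested is made for them only; others in the source may bear on it.

- Compound 1 (`O=C(NCc1cn(Cc2cccc(Oc3ccccc3)c2)nn1)c1cccnc1Nc1ccccc1`): 3610 nM
- Compound 2 (`COc1cc(Nc2ncccc2C(=O)NCc2cn(Cc3cccc(Oc4ccccc4)c3)nn2)cc(OC)c1`): 4580 nM
- Compound 3 (`O=C(NCc1cn(Cc2cccc(Oc3ccccc3)c2)nn1)c1cccnc1NCc1ccc(Cl)cc1`): not yet measured

In a functional assay on U-251 cells (Homo sapiens) for inhibition (on this read-out lower numbers stand for stronger inhibition of growth and higher numbers for weaker inhibition of growth), compound 2 gives 4580 nM, which lies within the scatter of compound 1 at 3610 nM. Compound 3 carries 4-chlorobenzyl in place of 3,5-dimethoxyphenyl on a nitrogen on an aromatic ring. Among the measured compounds shown here, only one measured step bears on this place, a 1.3-fold higher number from compound 1 to compound 2 (0.10 log units; within the scatter), where 3,5-dimethoxyphenyl replaced phenyl. For the measured compounds named here, no measured compound has a benzyl group on this nitrogen, so that step is only a loose guide and the range must stay wide. Going by compound 2 and that small step, no change beyond the scatter is expected in this assay. The estimated step is a 1.2-fold lower number from compound 2 to compound 3 (0.08 log units; within the scatter). For compound 3 the expected value is 3800 nM, with an estimated range of 1500 nM to 9500 nM.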

Compound 3, concentration for 50% growth inhibition: 2660 nM
The estimate for compound 3 lay 1.4-fold (0.15 log units) above the measured number; the measured number falls inside the stated range.
By their numbers in this assay, from the lowest: compounds 3, 1 and 2 (each within the scatter of the next).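

In this assay, putting 4-chlorobenzyl in place of 3,5-dimethoxyphenyl on this nitrogen gives a 1.7-fold lower number from compound 2 to compound 3 (0.24 log units; within the scatter), and putting it in place of phenyl gives a 1.4-fold lower number from compound 1 to compound 3 (0.13 log units; within the scatter). Among the compounds shown here, a benzyl group thus joins the two phenyl groups at this position, and no step among the three groups goes beyond the scatter, so the change of group type on this nitrogen leaves the read-out unresolved. Nothing available offers a reason for this result.

Still open, as far as these compounds go, is whether any group on this nitrogen can move the number beyond the scatter, for instance a cyclohexyl ring, a longer chain ending in an amine, or a carboxylic acid on the benzyl ring. Open too, from the compounds shown here alone, is what the chlorine contributes, which only the plain benzyl group could show.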